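The compounds below may be only part of what the source reports. "The series", "measured", "known", "first", "only" and "open" are said of these compounds alone.

Of the compounds shown here, three that share one core have been measured in an assay on isolated protein for binding affinity to Apoptosis regulator Bcl-2 (Homo sapiens), read by ELISA, with stated times of 1 h and 2 h; a lower number here means a stronger inhibitor, a higher number a weaker inhibitor. Compound 1 `O=[N+]([O-])c1ccc(Nc2nnc(-c3c[nH]c4ccccc34)o2)cc1` gives 3830 nM. Compound 2 `Clc1cccc(Nc2nnc(-c3c[nH]c4ccccc34)o2)c1` gives 660 nM, the lowest number of the set. Compound 3 `Cc1ccc(Nc2nnc(-c3c[nH]c4ccccc34)o2)cc1` gives 21100 nM, the highest number of the three, so among these it is the weakest inhibitor. Two steps lead to it: a 5.5-fold higher number from compound 1 to compound 3 (0.74 log units; beyond the scatter), and a 32-fold higher number from compound 2 to compound 3 (1.50 log units; beyond the scatter).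

Compound 4 `COc1ccc(Nc2nnc(-c3c[nH]c4ccccc34)o2)cc1` is the next to be measured. It differs from compound 3 in one place: methoxy in place of methyl on an aromatic carbon. Going by the values given here, of the measured steps, the one from compound 1 to compound 3 bears on this most, because a 5.5-fold higher number from compound 1 to compound 3 (0.74 log units; beyond the scatter) concerns a swap on the same aromatic carbon, where nitro rather than methyl went with the lower number. The step from compound 2 to compound 3 exchanges the whole attached ring and is a less direct guide, though it shows that changes in this part of the molecule can be large. Methoxy is a small change from methyl, so a modest move toward a lower number, or none beyond the scatter, is expected. For compound 4 the estimate is 12000 nM, within a range from 4000 nM to 35000 nM. That expectation amounts to a 1.8-fold lower number from compound 3 to compound 4 (0.25 log units; within the scatter).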

Compound 4, half-maximal inhibitory concentration: 29100 nM
The estimate for compound 4 lay 2.4-fold (0.38 log units) below the measured number; the measured number falls inside the stated range.
By their numbers in this assay, from the lowest: compound 2; then compound 1; then compounds 3 and 4 (each within the scatter of the next).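

In this assay, putting methoxy in place of methyl on this aromatic carbon gives only a small shift (a 1.4-fold higher number from compound 3 to compound 4 (0.14 log units; within the scatter)), so the extra oxygen, with its hydrogen-bond acceptor, does not separate these two compounds. Going by these compounds alone, the comparison with nitro on the same carbon is clearer (a 7.6-fold higher number from compound 1 to compound 4 (0.88 log units; beyond the scatter)) and resembles the earlier swap of nitro for methyl (a 5.5-fold higher number from compound 1 to compound 3 (0.74 log units; beyond the scatter)), so two different replacements for nitro now both go with a higher number, though only three groups have been compared at this position. No measurement available here explains why nitro differs from the other two groups or why methyl and methoxy stay so close.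

Still open, from the compounds shown here alone, is whether an amine, a carboxylic acid or a longer chain such as ethoxy on this aromatic carbon would stay with methyl and methoxy, match nitro or give a lower number than either. Also open, going by these compounds, is whether chloro on this same carbon would come close to the number for compound 2 (660 nM), which would help separate the effect of the group from the effect of where it sits.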